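The compounds below may be only part of what the source reports. "The series", "measured", "known", "first", "only" and "open" are said of these compounds alone.

Of the compounds shown here, three sharing one core have been measured in an assay on membranes from brain for displacement of a labelled ligand from Neuronal acetylcholine receptor; alpha4/beta2 (Rattus norvegicus); a lower number here means a stronger inhibitor, a higher number a weaker inhibitor. Compound 1 `CN1CCC[C@H]1COc1cnccc1Br` gives 28 nM. Compound 2 `CN1CCC[C@H]1COc1cncc(Cl)c1` gives 0.6 nM, and compound 3 `Cc1cncc(OC[C@@H]2CCCN2C)c1` gives 0.48 nM. Compound 3 stands at the lowest of the three numbers; its nearest neighbour is compound 2, and the step of a 1.3-fold lower number from compound 2 to compound 3 (0.10 log units; within the scatter) lies within the scatter, whereas compound 1 sits far higher, well beyond the scatter.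

The unmeasured compound 4 `CCCc1cncc(OC[C@@H]2CCCN2C)c1` differs from compound 3 in one place: ethyl in place of hydrogen on a saturated chain carbon bound to an aromatic carbon. Going by the values given here, none of the measured steps covers a change of this kind. Among the compounds with values here, the only single-point step, a 1.3-fold lower number from compound 2 to compound 3 (0.10 log units; within the scatter), swaps chloro for methyl on an aromatic carbon and says nothing about lengthening a chain. The gap between compound 1 and the other two is wide, but it involves a different group at a different place on the ring.

Within the data shown here, with no direct precedent among the measured compounds, a modest rise in the number is expected for compound 4, a 3.1-fold higher number from compound 3 to compound 4 (0.49 log units; beyond the scatter), as the chain grows beyond methyl, though a result within the scatter of compound 3 cannot be excluded. Compound 4 is therefore estimated at 1.5 nM, with a range from 0.4 nM to 6 nM.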

Compound 4, inhibition constant: 0.12 nM
The estimate for compound 4 lay 13-fold (1.10 log units) above the measured number; the whole stated range lies above it.
By their numbers in this assay, from the lowest: compound 4; then compounds 3 and 2 (each within the scatter of the next); then compound 1.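

Lengthening methyl to propyl on the shared core does not cost binding in this assay: the change gives a 4.0-fold lower number from compound 3 to compound 4 (0.60 log units; beyond the scatter), so this place takes on the added ethyl and the number falls beyond the scatter. Replacing chloro with propyl on the aromatic carbon gives a 5.0-fold lower number from compound 2 to compound 4 (0.70 log units; beyond the scatter), whereas the swap of chloro for methyl, a 1.3-fold lower number from compound 2 to compound 3 (0.10 log units; within the scatter), stayed within the scatter, so at this place the compounds separate only once the longer chain is present. Nothing given here bears on why the longer chain comes with the lower number.

The compounds shown stop at propyl, so it remains open whether butyl or a still longer chain would lower the number further or reverse the trend, and whether a branched chain such as isopropyl or a ring such as cyclopropyl would behave as propyl does. Also open, as far as these compounds go, is how a chain ending in a hydroxyl group or an amine would fare at this place, since every substituent here that extends beyond methyl is plain carbon and hydrogen.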